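Swapping the aryl group on a hydrazone-linked nucleoside

The source may hold more compounds than are shown below. What is called first, only, known or untested is meant among the compounds shown, and "the series" means these compounds.

Compound 2 `N#Cc1ccccc1/C=N/Nc1nc(N)c2ncn([C@@H]3O[C@H](CO)[C@@H](O)[C@H]3O)c2n1` and compound 1 `Nc1nc(N/N=C/c2ccc(-c3ccccn3)cc2)nc2c1ncn2[C@@H]1O[C@H](CO)[C@@H](O)[C@H]1O` differ in the aryl group hanging from the hydrazone. In an assay on CHO-K1 cells for displacement of a labelled ligand from adenosine receptor A1 (Homo sapiens), read by scintillation counting, with a stated time of 60 min (on this read-out lower numbers stand for stronger inhibition and higher numbers for weaker inhibition), compound 2 gives 2.9 nM, the lowest of the two numbers shown, while compound 1 gives 7540 nM, a gap well beyond the usual scatter. Compound 3 `CN(C)c1ccc(/C=N/Nc2nc(N)c3ncn([C@@H]4O[C@H](CO)[C@@H](O)[C@H]4O)c3n2)cc1` keeps the core of compound 2 but carries a different aryl group: 4-(dimethylamino)phenyl in place of 2-cyanophenyl on a carbon with a double bond to nitrogen. Among the measured compounds shown here, with no measured pair sharing this exact change, the outcome is uncertain, yet the weak number of compound 1 suggests the aryl group matters. The expected step of a 34-fold higher number from compound 2 to compound 3 (1.54 log units; beyond the scatter) is toward weaker binding, and compound 3 is estimated at 100 nM, within 10 nM to 1000 nM.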

Compound 3, inhibition constant: > 10000 nM
Compound 3 was reported as a limit (the forecaster's own chance of this, stated with the estimate: 5%); middle value at least 100-fold (2.00 log units) away from the limit.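

Compound 3 is reported only as a limit of the assay, not as a number: the limit of > 10000 nM in this assay, at which 1 of the 3 values shown sits. On the carbon with a double bond to nitrogen, 4-(dimethylamino)phenyl in place of 2-cyanophenyl gives an at least 3400-fold higher number from compound 2 to compound 3 (3.53 log units; beyond the scatter), so a single aryl swap here can lose nearly all the binding. Against compound 1 the floor is only an at least 1.3-fold higher number from compound 1 to compound 3 (0.12 log units; that floor lies within the scatter), so no order between those two can be stated. Going by these compounds, how much of the strong binding of compound 2 depends on its nitrile stays open. A plain phenyl or a 2-chlorophenyl group on the same carbon would help to separate the two groups' contributions.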